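Lengthening the hydroxamate linker of compound 1

This account rests on a few compounds, and the source may have more. Where it says the series, first, only, none or still open, it means among the compounds named here.

Measured compounds:
compound 1 `Cn1cc(-c2ccccc2Oc2ccccc2)c2cc(C(=O)NCCCC(=O)NO)[nH]c2c1=O`: 144 nM
compound 2 `CC(C)Oc1ccc(C(C)(C)O)cc1-c1cn(C)c(=O)c2[nH]c(C(=O)NCCCCCCC(=O)NO)cc12`: 5.4 nM
compound 3 `O=C(CCCCCCC(=O)Nc1cnc(N(c2ccccc2)c2ccccc2)nc1)NO`: 4.4 nM

Of the compounds shown here, three have been tested in an assay on isolated protein for inhibition of protein deacetylase HDAC6 (Homo sapiens), read by fluorescence; a higher number here means a weaker inhibitor, a lower number a stronger inhibitor. Compound 1 gives 144 nM, which is the highest of the three numbers. The nearest of the other two is compound 2, which gives 5.4 nM, a gap that lies beyond the scatter of repeated measurements. Compound 3 gives 4.4 nM, a still wider gap, also beyond the scatter. Compound 1 is thus the weakest inhibitor among the measured set.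

Compound 4 `Cn1cc(-c2ccccc2Oc2ccccc2)c2cc(C(=O)NCCCCCC(=O)NO)[nH]c2c1=O` keeps the core of compound 1 and changes only the chain that carries the hydroxamate:

2-(hydroxycarbamoyl)ethyl in place of hydroxycarbamoyl on a saturated chain carbon, three bonds along the chain from an amide-type nitrogen

Among the compounds with values here, no pair of measured compounds differs in one place only, so no measured step sets a scale for this change. Still, compound 1 stands far above compounds 2 and 3, both of which carry longer chains toward the hydroxamate, and the move from compound 1 to compound 4 goes in that direction. The step of a 9.6-fold lower number from compound 1 to compound 4 (0.98 log units; beyond the scatter) is therefore expected to be a clear lowering of the number, beyond the scatter. Compound 4 is estimated at 15 nM, with a range from 5 nM to 50 nM.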

Compound 4, half-maximal inhibitory concentration: 3.4 nM
Estimate against measurement, compound 4: 4.4-fold (0.64 log units) above; measured number outside the range, below it.
By their numbers in this assay, from the lowest: compounds 4, 3 and 2 (each within the scatter of the next); then compound 1.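

In this assay, within the data shown here, the step of a 42-fold lower number from compound 1 to compound 4 (1.63 log units; beyond the scatter) is the first measured change in which only the chain differs: with the shared core held fixed, 2-(hydroxycarbamoyl)ethyl replaces hydroxycarbamoyl on a saturated chain carbon, three bonds along the chain from an amide-type nitrogen. Compounds 2 and 3 also carry longer chains than compound 1, but each differs from it in more than one place, so their values could not separate the chain from the rest of the structure; this pair shows that lengthening the chain alone is enough for a large lowering of the number, beyond the scatter. The data offer nothing that explains why this lengthening has so large an effect.

With only two chain lengths on this core, the compounds shown leave open whether the number keeps falling with a longer chain such as 4-(hydroxycarbamoyl)butyl, or levels off or rises again. They also leave open whether the same lengthening would have a comparable effect with a different aryl group on the core, or whether a carboxylic acid at the chain end could take the place of the hydroxamate.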